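A few compounds are considered here, and "the series" means these few. Any claim that something is new, unique, unknown or untested is made for them only; others in the source may bear on it.

Compound 1 `Cc1ccccc1C(=O)Nc1ncc(-c2ccccc2)n1C`: > 100000 nM
Compound 2 `COc1ccc(-c2cnc(NC(=O)c3ccc(Br)cc3)n2C)cc1`: > 100000 nM

Both values in a toxicity assay on THP-1 cells (Homo sapiens) for inhibition (on this read-out lower numbers stand for higher toxicity in this test and higher numbers for lower toxicity in this test), are limits of the assay, not numbers. Compound 1 gives > 100000 nM in this assay, a limit only. Compound 2 likewise gives > 100000 nM in this assay, a limit only. Compound 2 therefore stands at the limit of > 100000 nM in this assay, at which 2 of the 2 values shown sit, with nothing to rank it against. Among the measured compounds shown here, no pair of measured compounds differs in one place, so no measured step exists. Compound 3 `COc1ccc(-c2cnc(NC(=O)c3ccc(O)cc3)n2C)cc1` differs from compound 2 by hydroxy in place of bromo on an aromatic carbon. For this change no step beyond the scatter is expected in this assay; compound 3 is expected to remain at the limit, an expected step of a number no higher from compound 2 to compound 3 (the limit leaves the size open). Compound 3 is estimated at 100000 nM, within 50000 nM to 300000 nM.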

Compound 3, half-maximal cytotoxic concentration: > 100000 nM
Compound 3: a limit, no number; the forecaster's own chance of this, stated with the estimate: 80%; the middle value sits exactly at the limit.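

In this assay compound 3 gives > 100000 nM, a limit of the assay. Among the compounds shown here, compound 2 gives > 100000 nM, also a limit, so no step between compound 2 and compound 3 can be read. The compounds shown leave open what change in the series, if any, would give a readable value in this assay.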